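Series notes: fluoro in place of trifluoromethyl, compound 3

The source may report more compounds than this note shows. Statements on the series, on what has been measured and on what is new or still open speak of the compounds shown alone.

Measured so far in an ADME assay on microsomes from liver (Mus musculus) for metabolic stability, read by LC-MS, with a stated time of 30 min, tested at 0.1 uM; on this read-out lower numbers stand for a less stable compound and higher numbers for a more stable compound:
compound 1 `COc1cccc(Nc2cc3[nH]c(-c4cccc(C(F)(F)F)c4)nc3cn2)n1`: 60%
compound 2 `Fc1ccc(-c2nc3cnc(Nc4cc(C(F)(F)F)ccn4)cc3[nH]2)cc1F`: 78%

Compound 2 stands highest of the two numbers in this assay; its nearest neighbour is compound 1, which sits lower by a gap beyond the usual scatter. Among the measured compounds shown here, the two differ in more than one place, so no single step is known between them.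

Compound 3 `Fc1ccnc(Nc2cc3[nH]c(-c4ccc(F)c(F)c4)nc3cn2)c1` differs from compound 2 in one place: fluoro in place of trifluoromethyl on an aromatic carbon. For the measured compounds named here, no measured pair shows this change, so the size of its step is unknown. Given that compound 2 gives 78% in this assay, a small step is expected, most likely none beyond the scatter, with a slight lowering more plausible than a rise. Compound 3 is therefore estimated at 70%, within 50% to 90%, which means an expected step of a number 8 percentage points lower from compound 2 to compound 3 (within the scatter).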

Compound 3, percent of the compound remaining in the Mus musculus assay: 18%
Compound 3: middle estimate off by 52 percentage points, on the high side; measured number below the stated range.
By their numbers in the Mus musculus assay, from the lowest: compound 3; then compound 1; then compound 2.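

At this position, an aromatic carbon opposite the ring nitrogen, fluoro in place of trifluoromethyl proves to be a large change, not a small one: in the Mus musculus assay the record is a number 60 percentage points lower from compound 2 to compound 3 (beyond the scatter) for this replacement. In a physicochemical assay for solubility, using the shake flask method, measured as kinetic solubility, with a stated time of 20 h, at pH 2 (a lower number here means a less soluble compound, a higher number a more soluble compound), compound 2 gives < 5000 nM as a limit of the assay and not a number. In the physicochemical assay compound 3 gives 166000 nM as a measured number. Among the compounds shown here, in the physicochemical assay the same change gives an at least 33-fold higher number from compound 2 to compound 3 (1.52 log units; beyond the scatter) and so the single replacement lowers the number in one read-out and raises it in the other.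

From the compounds shown here alone, it stays open whether another group at this position, such as a nitrile, an amine or a methyl, could keep a high number in both read-outs. Going by these compounds, it also stays open whether the two steps would carry over to the substituents of compound 1.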